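This account rests on a few compounds, and the source may have more. Where it says the series, first, only, none or still open, it means among the compounds named here.

Working notes on the series. In a functional assay on MCF7 cells (Homo sapiens) for antiproliferative activity, read by MTT assay, with a stated time of 48 h (on this read-out higher numbers stand for weaker inhibition and lower numbers for stronger inhibition), compound 2 `CC(C)=CCC[C@]1(C)/C=C/[C@@H](OC(=O)C=C(C)C)[C@](C)(O)/C=C/C(=O)/C(CN(C(C)C)C(C)C)=C\C1` holds the lower of the two measured numbers at 780 nM, while compound 1 `COC/C1=C/C[C@](C)(CCC=C(C)C)/C=C/[C@@H](OC(=O)C=C(C)C)[C@](C)(O)/C=C/C1=O` gives 4130 nM. Compound 3 `CC(C)=CCC[C@]1(C)/C=C/[C@@H](OC(=O)C=C(C)C)[C@](C)(O)/C=C/C(=O)/C(C[Si](C)(C)C(C)(C)C)=C\C1` differs from compound 2 by a group of 7 heavy atoms (6 carbon, 1 silicon; no ring) in place of a group of 7 heavy atoms (6 carbon, 1 nitrogen; no ring), on a saturated chain carbon bound to a double-bonded ring carbon. For the measured compounds named here, the only measured step at this place, a 5.3-fold lower number from compound 1 to compound 2 (0.72 log units; beyond the scatter), is modest and beyond the scatter. No group containing silicon has been measured, so the direction is uncertain, but a modest rise in the number is expected in this assay. The expected change is a 2.3-fold higher number from compound 2 to compound 3 (0.36 log units; beyond the scatter). For compound 3 the estimate is 1800 nM, with an expected range of 600 nM to 5000 nM.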

Compound 3, half-maximal inhibitory concentration: 6040 nM
Compound 3: middle estimate off by 3.4-fold (0.53 log units), on the low side; measured number outside the range, above it.
By their numbers in this assay, from the lowest: compound 2; then compounds 1 and 3 (each within the scatter of the next).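

In this assay, the silicon-bearing group, with the same count of heavy atoms as diisopropylamino, does not hold the number of compound 2, giving a 7.7-fold higher number from compound 2 to compound 3 (0.89 log units; beyond the scatter). Set against methoxy, the same group gives a 1.5-fold higher number from compound 1 to compound 3 (0.17 log units; within the scatter), within the scatter, so among these three groups only diisopropylamino stands apart, and heavy-atom count alone does not set the number. No measurement here accounts for the difference. Still open, from the compounds shown here alone, is whether another amine, such as dimethylamino, or a carboxylic acid on this carbon would match compound 2.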